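A few compounds are considered here, and "the series" means these few. Any claim that something is new, unique, unknown or untested is made for them only; others in the source may bear on it.

Compound 1, `CC(C)c1ccc(-c2nc(CN3CCCC3)nn2C)cc1`, gives 1000 nM in an assay on membranes from Jurkat cells for displacement of a labelled ligand from Sigma intracellular receptor 2 (Homo sapiens), read by scintillation counting, with a stated time of 1 h; on this read-out higher numbers stand for weaker inhibition and lower numbers for stronger inhibition.
Compound 2, `Cn1nc(CN2CCCC2)nc1-c1ccc(C(C)(C)C)cc1`, gives > 1000 nM in this assay, and that figure is a limit of the assay, not a number.

The two measured compounds share one core and differ only in the chain on the aromatic carbon, where compound 2 carries methyl in place of hydrogen. The step recorded there is a number no lower from compound 1 to compound 2 (the limit leaves the size open). Compound 2 therefore stands at the limit of > 1000 nM in this assay, at which 1 of the 2 values shown sits, and only a limit is known for it.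

Compound 3, `CC(C)(C)c1ccc(-c2nc(CN3CCCC3)nn2C2CC2)cc1`, differs from compound 2 by cyclopropyl in place of methyl on an aromatic nitrogen. Going by the values given here, none of the measured steps touches the group on the aromatic nitrogen, so no measured step bears directly on this change, and its size can only be guessed from how compound 2 stands. Because compound 2 gives > 1000 nM, compound 3 is expected to stay weak in this assay. The step from compound 2 to compound 3 is expected to be a step that the limit leaves unreadable from compound 2 to compound 3, that is, no change beyond the scatter. Compound 3 is estimated at 2000 nM, with a range from 500 nM to 8000 nM.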

Compound 3, inhibition constant: 750 nM
Estimate against measurement, compound 3: 2.7-fold (0.43 log units) above; low and high end bracket the measured number.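

Going by these compounds alone, until this result, no step touched the group on the aromatic nitrogen, so this is the first reading of that position: in this assay, cyclopropyl in place of methyl gives an at least 1.3-fold lower number from compound 2 to compound 3 (0.12 log units; that floor lies within the scatter). The position therefore accepts a ring of three carbons in place of a single carbon without the number rising, and compound 3 gives the series a measured value where compound 2 offers none. From the compounds shown here alone, the floor of this step lies within the scatter, so it does not by itself establish a real gain, and the full size of the step stays open because compound 2 carries only a limit: the limit of > 1000 nM in this assay, at which 1 of the 3 values shown sits.

Going by these compounds, what an ethyl or isopropyl group on the same nitrogen would give remains open, so these compounds cannot separate the effect of having a ring from that of simply adding carbon atoms. Also open, on these data alone, is whether cyclopropyl would give a similar result on a compound with the isopropyl chain of compound 1, and how a nitrogen-bearing group such as an amine would fare at this position.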